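The source may hold more compounds than are shown below. What is called first, only, known or untested is meant among the compounds shown, and "the series" means these compounds.

Working notes on the series. In a functional assay on THP-1 cells (Homo sapiens) for cytotoxicity, read by MTT assay, with a stated time of 24 h (a lower number here means a stronger inhibitor, a higher number a weaker inhibitor), compound 1 `C=C1CC[C@H]2C(C)(C)CCC[C@]2(C)[C@H]1CCC(C)CC(=O)O` gives > 200000 nM, which is a limit. Compound 2 `C=C1CC[C@H]2C(C)(C)CCC[C@]2(C)[C@H]1CCC(C)CC(=O)OC` gives > 200000 nM, also a limit. Compound 3 `CC(CC[C@H]1/C(=C/c2ccc(F)cc2)CC[C@H]2C(C)(C)CCC[C@]12C)CC(=O)O` gives > 200000 nM, again a limit and not a number. Within the data shown here, the series so far stands at the limit of > 200000 nM in this assay, at which 3 of the 3 values shown sit. Compound 4 `CC(CC[C@H]1/C(=C/c2ccc(I)cc2)CC[C@H]2C(C)(C)CCC[C@]12C)CC(=O)O` differs from compound 3 by iodo in place of fluoro on an aromatic carbon, with iodo in place of fluoro on an aromatic carbon. Among the measured compounds shown here, the only measured step is a step that the two limits leave unreadable from compound 1 to compound 2, at another place in the molecule, so it offers no size to carry over. With compound 3 at the limit of > 200000 nM, no step beyond the scatter is expected in this assay. The expected step is a number no higher from compound 3 to compound 4 (the limit leaves the size open). For compound 4 the estimated value is 200000 nM, with an expected range of 60000 nM to 400000 nM.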

Compound 4, half-maximal inhibitory concentration: 68000 nM
Estimate against measurement, compound 4: 2.9-fold (0.47 log units) above, within the range that was stated.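

In this assay, among these compounds, 4-fluorophenyl to 4-iodophenyl gives the only readable step, an at least 2.9-fold lower number from compound 3 to compound 4 (0.46 log units; beyond the scatter). Among the compounds shown here, this shows that a change at this position can bring a value off the limit, while the step between the two limit values of the earlier compounds cannot be read. Even so, most of the series gives no number: the limit of > 200000 nM in this assay, at which 3 of the 4 values shown sit.

On these data alone, whether chloro or bromo at this position would also give a readable step remains open. So does whether an amide in place of the carboxylic acid would retain the value of compound 4.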